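Ethyl in Place of Acetyl on the Ring Nitrogen

A few compounds are considered here, and "the series" means these few. Any claim that something is new, unique, unknown or untested is made for them only; others in the source may bear on it.

Three measured compounds share one core and differ only at an amine nitrogen in a ring. Compound 1 `N#Cc1ccc(Nc2nc(Oc3ccnc4ccccc34)nc(N3CCN(c4ccccc4)CC3)n2)cc1C(F)(F)F` in a functional assay on DU-145 cells (Homo sapiens) for cytotoxicity, read by sulforhodamine B assay, with a stated time of 48 h (a lower number here means a stronger inhibitor of growth, a higher number a weaker inhibitor of growth), gives only a limit, > 100000 nM. Compound 2 `N#Cc1ccc(Nc2nc(Oc3ccnc4ccccc34)nc(N3CCN(c4ccccc4F)CC3)n2)cc1C(F)(F)F` likewise reaches only the limit > 100000 nM. Going by the values given here, compound 3 `CC(=O)N1CCN(c2nc(Nc3ccc(C#N)c(C(F)(F)F)c3)nc(Oc3ccnc4ccccc34)n2)CC1` is the single compound with a measured number, 75100 nM, and so stands as the sole real reading. The steps of an at least 1.3-fold lower number from compound 1 to compound 3 (0.12 log units; that floor lies within the scatter) and an at least 1.3-fold lower number from compound 2 to compound 3 (0.12 log units; that floor lies within the scatter) replace phenyl or 2-fluorophenyl with acetyl on that nitrogen. Compound 4 `CCN1CCN(c2nc(Nc3ccc(C#N)c(C(F)(F)F)c3)nc(Oc3ccnc4ccccc34)n2)CC1` carries the change (ethyl in place of acetyl on an amine nitrogen in a ring). Among the compounds with values here, no measured step involves ethyl, and the two known steps are floors within the scatter. For compound 4 the step expected is a 1.1-fold higher number from compound 3 to compound 4 (0.03 log units; within the scatter), none beyond the scatter. Compound 4 is estimated at 80000 nM, between 30000 nM and 200000 nM.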

Compound 4, concentration for 50% growth inhibition: 86600 nM
Compound 4: middle estimate off by 1.1-fold (0.03 log units), on the low side; low and high end bracket the measured number.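

Putting ethyl in place of acetyl on this ring nitrogen removes the carbonyl, yet the result is only a 1.2-fold higher number from compound 3 to compound 4 (0.06 log units; within the scatter), so in this assay the two groups cannot be told apart. The steps of an at least 1.1-fold lower number from compound 2 to compound 4 (0.06 log units; that floor lies within the scatter) and an at least 1.1-fold lower number from compound 1 to compound 4 (0.06 log units; that floor lies within the scatter) remain only floors, because the phenyl and 2-fluorophenyl partners sit at a limit of the assay: the limit of > 100000 nM in this assay, at which 2 of the 4 values shown sit.

From the compounds shown here alone, what a longer alkyl chain, a carboxylic acid or a free amine at this nitrogen would do remains open. So does whether any group here can give a step beyond the scatter.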